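The source may hold more compounds than are shown below. What is called first, only, known or untested is meant among the compounds shown, and "the series" means these compounds.

Measured compounds, inhibition in an assay on isolated protein for inhibition of glucose-6-phosphatase catalytic subunit 1 (Homo sapiens), tested at 100 uM; on this read-out higher numbers stand for more inhibition at the one concentration tested (going by the name of the read-out) and lower numbers for less inhibition:
- compound 1 `COc1ccc(-c2c(C#N)c(N)c(C#N)c(SC)c2-c2ccccc2)cc1` gives 37.9%
- compound 2 `COc1ccc(-c2c(C#N)c(N)c(C#N)c(SC)c2-c2ccc(F)cc2)cc1` gives "not active" (no number reported)
- compound 3 `CSc1c(C#N)c(N)c(C#N)c(C)c1-c1ccccc1F` gives 20%

Compound 3 stands lowest of the two numbers in this assay; the nearest number is that of compound 1, which lies higher by a gap beyond the usual scatter. Compound 2 has no number, only the report that it is not active.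

Compound 4 `CSc1c(C#N)c(N)c(C#N)c(C)c1-c1ccc(F)cc1` differs from compound 3 in one place: 4-fluorophenyl in place of 2-fluorophenyl on an aromatic carbon

Among the compounds with values here, no step between measured compounds is available for this change. Within the data shown here, the only measured compound carrying a 4-fluorophenyl is compound 2, and in this assay compound 2 gives "not active" (no number reported), while compound 1, which carries an unsubstituted phenyl in that place on a different core, gives 37.9%. On that basis a downward step from compound 3 to compound 4 is expected, of moderate size, a number 10 percentage points lower from compound 3 to compound 4 (within the scatter), with a real chance that only a limit is reported. For compound 4 the expected value in this assay is 10%, within a range of 0% to 25%.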

Compound 4, a percentage reported as inhibition, at one concentration (the size of the read-out at that concentration, not a potency): 5%
The estimate for compound 4 lay 5 percentage points above the measured number; low and high end bracket the measured number.
By their numbers in this assay, from the lowest: compound 4; then compound 3; then compound 1.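

With the shared core held fixed, 4-fluorophenyl in place of 2-fluorophenyl on the aromatic carbon ortho to a methyl group and a methylsulfanyl group gives a modest step in this assay: a number 15 percentage points lower from compound 3 to compound 4 (beyond the scatter). Within the data shown here, this is the first comparison between two compounds that differ in one place, and it shows that the read-out at this position depends on where the fluorine sits on the phenyl ring, not only on whether fluorine is present. Nothing measured here accounts for the difference between the two fluorophenyl groups.

Among these compounds, compound 2 also carries a 4-fluorophenyl but has no number, so no step on the core of compound 1 can be read. Still open, from the compounds shown here alone, is how a chlorine or a methoxy group in place of the fluorine of compound 3 or compound 4 would read.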